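Swapping the oxolan-3-yl group of compound 1

The source may hold more compounds than are shown below. What is called first, only, known or untested is meant among the compounds shown, and "the series" means these compounds.

- compound 1 `COc1cc(-c2cnn3cc(OC)c(C4CCOC4)nc23)ccn1`: 34%
- compound 2 `COc1cn2ncc(-c3ccnc(OC(C)(C)C)c3)c2nc1-c1cnn(C)c1`: 61%
- compound 3 `Cn1cc(-c2nc3c(-c4ccnc(OC5CC5)c4)cnn3cc2OCC(C)(C)O)cn1`: 81%

All three compounds were tested in an ADME assay on microsomes from liver (Rattus norvegicus) for metabolic stability, with a stated time of 60 min, tested at 1 uM; on this read-out higher numbers stand for a more stable compound and lower numbers for a less stable compound. Compound 1 stands lowest of the three, and both others lie above it by more than the scatter: compound 2 gives 61% and compound 3 gives 81%.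

The next compound, compound 4 `COc1cc(-c2cnn3cc(OC)c([C@H]4COC(C)(C)C4)nc23)ccn1`, keeps the core of compound 1 and changes one group on an aromatic carbon: a group of 7 heavy atoms (6 carbon, 1 oxygen; one five-membered non-aromatic ring with 1 hetero atom) in place of a group of 5 heavy atoms (4 carbon, 1 oxygen; one five-membered non-aromatic ring with 1 hetero atom), on an aromatic carbon. Going by the values given here, no two measured compounds differ in only one place, so the data offer no direct precedent for this swap. Compound 1 at 34% leaves room for a rise, but nothing yet shows that this change will deliver one. A modest upward move is the expectation, with a real chance of no change beyond the scatter. The estimated step of a number 13 percentage points higher from compound 1 to compound 4 (beyond the scatter) is therefore upward but uncertain. For compound 4 the expected value is 47%, with an estimated range of 28% to 68%.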

Compound 4, percent of the compound remaining: 30%
Estimate against measurement, compound 4: 17 percentage points above, and the stated range covers the measured number.
By their numbers in this assay, from the lowest: compounds 4 and 1 (each within the scatter of the next); then compound 2; then compound 3.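

Going by these compounds alone, compound 1 and compound 4 form the first pair here that differs in one place only, so they give the first direct reading at this position, on an aromatic carbon next to the ring nitrogen. In this assay, replacing oxolan-3-yl with the group of 7 heavy atoms, which keeps the five-membered non-aromatic ring and has 1 defined stereocentre, gives a number 4 percentage points lower from compound 1 to compound 4 (within the scatter), so this swap leaves the two compounds indistinguishable on this read-out. Nothing available explains this outcome.

Compound 2 and compound 3 differ from compound 1 in more than one place, so their numbers say nothing about this position alone. From the compounds shown here alone, whether an amine or a carboxylic acid at this position would shift the number remains open.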